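Pyridin-4-yl to pyridin-3-yl: working notes

A few compounds are considered here, and "the series" means these few. Any claim that something is new, unique, unknown or untested is made for them only; others in the source may bear on it.

In a functional assay on PC-3 cells (Homo sapiens) for cytotoxicity, read by WST assay, with a stated time of 72 h (on this read-out higher numbers stand for weaker inhibition and lower numbers for stronger inhibition), compound 1 (`O=C1Nc2c(ccc(F)c2F)C1(c1ccc(O)cc1)c1cccs1`) gives 0.3 nM and compound 2 (`O=C1Nc2c(ccc(F)c2F)C1(c1ccncc1)c1ccc(O)cc1`) gives 110 nM as the higher of the two numbers. Compound 3 (`O=C1Nc2c(ccc(F)c2F)C1(c1ccc(O)cc1)c1cccnc1`) carries pyridin-3-yl in place of pyridin-4-yl on a saturated ring carbon and is still unmeasured. Going by the values given here, the one measured step at this place is large and beyond the scatter (a 370-fold higher number from compound 1 to compound 2 (2.56 log units; beyond the scatter)) but involves no pyridin-3-yl group. A moderate move toward a lower number is therefore expected in this assay with wide uncertainty. The expected step is (a 5.5-fold lower number from compound 2 to compound 3 (0.74 log units; beyond the scatter)). Compound 3 is estimated at 20 nM within an expected range from 2 nM to 150 nM for now.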

Compound 3, half-maximal inhibitory concentration: > 1000 nM
Compound 3 ended at the assay's limit; the forecaster's own chance of this, stated with the estimate: 3%; at least 50-fold (1.69 log units) between middle value and limit.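

Compound 3 stands at a limit of the assay, not at a number: the limit of > 1000 nM in this assay, at which 1 of the 3 values shown sits. Pyridin-3-yl in place of pyridin-4-yl, the same atoms joined differently, gives an at least 9.0-fold higher number from compound 2 to compound 3 (0.95 log units; beyond the scatter), so this saturated ring carbon separates two groups of identical composition. Pyridin-3-yl in place of thiophen-2-yl gives an at least 3300-fold higher number from compound 1 to compound 3 (3.52 log units; beyond the scatter), and in this assay both pyridine-bearing compounds lie far from compound 1.

From the compounds shown here alone, whether phenyl or thiophen-3-yl at this place would stay near compound 1 remains open. Going by these compounds, how far compound 3 lies past its limit also remains open, so the full size of both steps is unknown.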